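The source may report more compounds than this note shows. Statements on the series, on what has been measured and on what is new or still open speak of the compounds shown alone.

Compound 1 `Cc1nn(C)c(Oc2cccc(F)c2F)c1/C=N\CCCCCCOc1cc2oc(=O)cc(C)c2cc1Cl` gives > 25000 nM in a functional assay on HepG2 cells (Homo sapiens) for antiproliferative activity, read by MTT assay, with a stated time of 72 h (on this read-out higher numbers stand for weaker inhibition and lower numbers for stronger inhibition), which is a limit of the assay rather than a number. Compound 2 `Cc1nn(C)c(Oc2ccc(F)cc2F)c1/C=N\CCCCCCOc1cc2oc(=O)cc(C)c2cc1Cl` gives > 25000 nM in this assay, again only a limit.

Compound 2 therefore sits at the limit of > 25000 nM in this assay, at which 2 of the 2 values shown sit, where every measured value rests. Among the measured compounds shown here, the only measured step, a step that the two limits leave unreadable from compound 1 to compound 2, gives no readable size. Compound 3 `Cc1ccccc1Oc1c(/C=N\CCCCCCOc2cc3oc(=O)cc(C)c3cc2Cl)c(C)nn1C` differs from compound 2 by 2-methylphenyl in place of 2,4-difluorophenyl on an oxygen on an aromatic ring. For the measured compounds named here, no measured step shows what this change does, so the expectation rests on the two limits alone. Compound 3 is expected to give 35000 nM, within 8000 nM to 150000 nM, most likely reported again as a limit. The expected step from compound 2 is a step that the limit leaves unreadable from compound 2 to compound 3.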

Compound 3, half-maximal inhibitory concentration: 7830 nM
For compound 3 the middle estimate is 4.5-fold (0.65 log units) above the measured one, outside the stated range (below it).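

In this assay the group on this oxygen can change the result: an at least 3.1-fold lower number from compound 2 to compound 3 (0.50 log units; beyond the scatter) and an at least 3.1-fold lower number from compound 1 to compound 3 (0.50 log units; beyond the scatter) both come with 2-methylphenyl entering in place of a difluorophenyl group. The two difluorophenyl compounds alone could not show this. Each step gives only a minimum size, because the starting compounds give no number: the limit of > 25000 nM in this assay, at which 2 of the 3 values shown sit.

On these data alone, whether the change goes with the methyl group or with the loss of fluorine stays open. A plain phenyl or a chlorophenyl group on the same oxygen would bear on that question.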